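A few compounds are considered here, and "the series" means these few. Any claim that something is new, unique, unknown or untested is made for them only; others in the source may bear on it.

Compound 3 `CC(C(=O)NCc1ccc(C(F)(F)F)nc1N1CCC(C)(C)CC1)c1ccc(NS(C)(=O)=O)c(F)c1` is the reference point of this account. In a functional assay on CHO-K1 cells for antagonist activity at transient receptor potential cation channel subfamily V member 1 (Homo sapiens), read by FLIPR (a lower number here means a stronger inhibitor, a higher number a weaker inhibitor), compound 3 gives 0.3 nM, the lowest of the three numbers measured. Its nearest neighbour is compound 2 `CCCCN(C)c1nc(C(F)(F)F)ccc1CNC(=O)C(C)c1ccc(NS(C)(=O)=O)c(F)c1`, which in this assay gives 0.8 nM; the step between them is a 2.7-fold lower number from compound 2 to compound 3 (0.43 log units; beyond the scatter). The furthest is compound 1 `Cc1ccc(Cl)cc1Nc1nc(C(F)(F)F)ccc1CNC(=O)C(C)c1ccc(NS(C)(=O)=O)c(F)c1`, which in this assay gives 14 nM; that step is a 47-fold lower number from compound 1 to compound 3 (1.67 log units; beyond the scatter), and the related change from the (5-chloro-2-methylphenyl)amino group to butyl(methyl)amino is an 18-fold lower number from compound 1 to compound 2 (1.24 log units; beyond the scatter).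

Compound 4 `CC(C(=O)NCc1ccc(C(F)(F)F)nc1N1CCN(C)CC1)c1ccc(NS(C)(=O)=O)c(F)c1` is not yet measured. It differs from compound 3 in one place: 4-methylpiperazin-1-yl in place of 4,4-dimethylpiperidin-1-yl on an aromatic carbon. The step that bears most directly on it is a 2.7-fold lower number from compound 2 to compound 3 (0.43 log units; beyond the scatter), a modest one between two groups on the same aromatic carbon; the two large steps both concern the removal of the (5-chloro-2-methylphenyl)amino group and say little about an exchange between two saturated rings. For the measured compounds named here, no measured pair swaps a ring with one hetero atom for a ring with two, so the direction is uncertain; a modest movement toward a higher number is expected, of about the size of the one modest step seen. For compound 4 in this assay the estimate is 3 nM, in a range from 0.8 nM to 12 nM. The expected step is therefore a 10-fold higher number from compound 3 to compound 4 (1.00 log units; beyond the scatter).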

Compound 4, inhibition constant: 146 nM
The estimate for compound 4 lay 49-fold (1.69 log units) below the measured number; the whole stated range lies below it.
By their numbers in this assay, from the lowest: compound 3; then compound 2; then compound 1; then compound 4.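

In this assay, the earlier compounds had shown this position, on an aromatic carbon next to the ring nitrogen, carrying butyl(methyl)amino and 4,4-dimethylpiperidin-1-yl with only a modest difference, but 4-methylpiperazin-1-yl in place of 4,4-dimethylpiperidin-1-yl gives a 490-fold higher number from compound 3 to compound 4 (2.69 log units; beyond the scatter) and is the largest step in the set. The same group also falls behind the open-chain butyl(methyl)amino, with a 180-fold higher number from compound 2 to compound 4 (2.26 log units; beyond the scatter) as the step, and behind the (5-chloro-2-methylphenyl)amino group, with a 10-fold higher number from compound 1 to compound 4 (1.02 log units; beyond the scatter) as the step, so that group no longer gives the highest number of the series. Among the four compounds, then, the position does not treat all saturated amines alike: two six-membered non-aromatic rings, one with 1 hetero atom and one with 2, stand at opposite ends of the order.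

Nothing in the data at hand accounts for the size of this step. The compounds shown do not separate the second ring nitrogen from the methyl group on it, a question on which plain piperidin-1-yl, morpholin-4-yl, or a piperazin-1-yl ring carrying a hydrogen or an acetyl group on that nitrogen would bear.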